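Aryl swap on the saturated chain carbon

The source may hold more compounds than are shown below. What is called first, only, known or untested is meant among the compounds shown, and "the series" means these compounds.

For the measured compounds named here, compound 2 `O=C(C1CC1)N1CCN(Cc2nc3ccccc3n2Cc2ccc(C(F)(F)F)cc2)CC1` stands highest of the two numbers so far in an assay on isolated protein for inhibition of aldehyde dehydrogenase 1A1 (Homo sapiens), read by spectrophotometry, tested at 10 uM (a lower number here means less inhibition, a higher number more inhibition at the concentration tested (going by the name of the read-out)), giving 37%. Compound 1 `CCn1c(CN2CCN(C(=O)C3CC3)CC2)nc2ccccc21` gives 20.8%. Going by the values given here, the one measured step, a number 16.2 percentage points higher from compound 1 to compound 2 (beyond the scatter), sets methyl against 4-(trifluoromethyl)phenyl and so bears only partly on the next change. Compound 3 `O=C(C1CC1)N1CCN(Cc2nc3ccccc3n2Cc2cccc(Cl)c2)CC1` differs from compound 2 by 3-chlorophenyl in place of 4-(trifluoromethyl)phenyl on a saturated chain carbon bound to an aromatic nitrogen. Both groups are six-membered aromatic rings of carbon only. The step is expected to be about a number 6 percentage points lower from compound 2 to compound 3 (within the scatter), not beyond the scatter. Compound 3 is therefore estimated at 31%, in the range 16% to 46%.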

Compound 3, a percentage reported as inhibition, at one concentration (the size of the read-out at that concentration, not a potency): 71.6%
Estimate against measurement, compound 3: 40.6 percentage points below, and the stated range ends below it.
By their numbers in this assay, from the lowest: compound 1; then compound 2; then compound 3.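

On the saturated chain carbon bound to an aromatic nitrogen, the choice of aryl group strongly shifts the result in this assay (a number 34.6 percentage points higher from compound 2 to compound 3 (beyond the scatter)), so 3-chlorophenyl and 4-(trifluoromethyl)phenyl are not interchangeable despite sharing one six-membered aromatic ring of carbon only. Against methyl, 3-chlorophenyl also gives a large gain (a number 50.8 percentage points higher from compound 1 to compound 3 (beyond the scatter)). No evidence here bears on the origin of this difference.

The substituent and its ring place change together, leaving their contributions unseparated; 4-chlorophenyl or 3-(trifluoromethyl)phenyl would separate them. Also open, going by these compounds, is how a pyridinyl ring would compare at this position.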